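Trading a triazole for a methylimidazole on the shared core

The source may hold more compounds than are shown below. What is called first, only, known or untested is meant among the compounds shown, and "the series" means these compounds.

Compound 1 `c1ccc(-c2nc[nH]n2)c(NCC2=NCCN2)c1`: 5.01 nM
Compound 2 `Cc1ccc(-c2ccccc2NCC2=NCCN2)n1C`: < 100000 nM

Among the compounds with values here, in an in vitro functional assay on cells (Fibroblast) for agonist activity at Alpha-1B adrenergic receptor (Homo sapiens) (a lower number here means that less compound is needed, a higher number that more compound is needed for the effect), compound 1 gives 5.01 nM, the only number among the values shown. For compound 2 the assay reports only a limit, (the limit of < 100000 nM in this assay, at which 1 of the 2 values shown sits). Within the data shown here, no step between measured compounds is available, so the change to compound 3 `Cn1ccnc1-c1ccccc1NCC1=NCCN1` rests on structure alone: 1-methyl-1H-imidazol-2-yl in place of 1H-1,2,4-triazol-3-yl on an aromatic carbon. With the hydrogen-bond donor of compound 1 gone, more compound is expected to be needed, a step beyond the scatter, a 10-fold higher number from compound 1 to compound 3 (1.00 log units; beyond the scatter). Compound 3 is therefore estimated at 50 nM, within 5 nM to 500 nM.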

Compound 3, half-maximal effective concentration: 39.8 nM
Compound 3: the middle estimate sits 1.3-fold (0.10 log units) above what was measured, within the range that was stated.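

In this assay, replacing 1H-1,2,4-triazol-3-yl with 1-methyl-1H-imidazol-2-yl on this aromatic carbon gives a 7.9-fold higher number from compound 1 to compound 3 (0.90 log units; beyond the scatter), a modest step. The hydrogen-bond donor of compound 1 is therefore not required for compound 3 to give a measured value in the nanomolar range. Compound 2 gives only a limit, so no step to it can be read: the limit of < 100000 nM in this assay, at which 1 of the 3 values shown sits.

The compounds shown leave open whether the step follows the lost donor or the added methyl, as the two changes come together here. They also leave open how a simple amine at this position would read.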